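Swapping a Fluorophenyl Ether for a Pyridyl Ether

This account rests on a few compounds, and the source may have more. Where it says the series, first, only, none or still open, it means among the compounds named here.

Of the compounds shown here, two that share one core have so far been tested in a functional assay on HEK293 cells for positive allosteric modulation of metabotropic glutamate receptor 5 (Homo sapiens), read by calcium flux; on this read-out higher numbers stand for larger maximal responses and lower numbers for smaller maximal responses. Compound 1 `O=C1c2cc(COc3ccccc3)nn2CCN1c1cccc(F)c1` reaches 81% in this assay. Compound 2 `O=C1c2cc(COc3ccccc3F)nn2CCN1c1ccc(F)cc1` reaches 66%, the lower of the two numbers, and the gap to compound 1 lies beyond the usual scatter; the two compounds differ in more than one place, so that gap cannot be tied to any single change. Compound 3 `O=C1c2cc(COc3cccnc3)nn2CCN1c1ccc(F)cc1` has not yet been measured. It differs from compound 2 in one place: pyridin-3-yl in place of 2-fluorophenyl on an oxygen on a saturated carbon. For the measured compounds named here, no measured pair shows this change, so nothing in the data sets its size or direction. The step from compound 2 to compound 3 is expected to be small, at most modest, as a number 4 percentage points higher from compound 2 to compound 3 (within the scatter). Compound 3 is therefore estimated at 70%, with a range from 50% to 92%.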

Compound 3, largest response reached (Emax), in percent of the reference or control that the assay uses: 69%
Compound 3: the middle estimate sits 1 percentage points above what was measured, and the stated range covers the measured number.
By their numbers in this assay, from the lowest: compounds 2 and 3 (each within the scatter of the next); then compound 1.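

For the compounds shown here, this is the first measured pair that differs in one place only, and in this assay it shows a number 3 percentage points higher from compound 2 to compound 3 (within the scatter) when pyridin-3-yl takes the place of 2-fluorophenyl on the oxygen. At this position, then, an aromatic ring of carbon only, bearing a fluorine, can give way to an aromatic ring with 1 hetero atom and 1 hydrogen-bond acceptor without the maximal response moving beyond the usual scatter. No measurement at hand bears on the reason for this result.

The compounds shown leave open whether the response also holds with other groups on that oxygen, such as a cyclohexyl ring, a pyrimidin-5-yl ring or a longer chain. They also leave open whether pyridin-3-yl would behave the same way on compound 1.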